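Imidazopyridine ethers: toward compound 4

The compounds below may be only part of what the source reports. "The series", "measured", "known", "first", "only" and "open" are said of these compounds alone.

Measured so far:
- compound 1 `CC#CC(CC(=O)O)c1ccc(OCc2ccn3cc(-c4ccccc4)nc3c2)cc1`: 1260 nM
- compound 2 `CC#CC(CC(=O)O)c1ccc(OCc2ccn3cc(-c4ccc(C(C)C)cc4)nc3c2)cc1`: 615 nM
- compound 3 `CC#CC(CC(=O)O)c1ccc(OCc2ccc3nc(-c4ccccc4)cn3c2)cc1`: 979 nM

In an assay on isolated protein for agonist activity at Free fatty acid receptor 1 (Homo sapiens) (a lower number here means that less compound is needed, a higher number that more compound is needed for the effect), compound 2 gives the lowest number of the three. Compound 3 lies within the scatter of it, so no order between compound 2 and compound 3 can be claimed. Among the compounds with values here, compound 1 sits beyond the scatter, and the step of a 2.0-fold lower number from compound 1 to compound 2 (0.31 log units; beyond the scatter) is the only single-point change measured.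

Compound 4 `CC#CC(CC(=O)O)c1ccc(OCc2ccn3cc(-c4ccccc4C)nc3c2)cc1` differs from compound 2 by 2-methylphenyl in place of 4-isopropylphenyl on an aromatic carbon. This change removes the isopropyl whose addition gave the step from compound 1 to compound 2 and brings in a methyl on a ring position for which no measurement exists. Within the data shown here, the one relevant step suggests that the number should move back toward that of compound 1, by a modest amount, with added uncertainty from the new methyl.

Compound 4 is therefore expected to give 1000 nM, with a range of 450 nM to 2200 nM, corresponding to an estimated step of a 1.6-fold higher number from compound 2 to compound 4 (0.21 log units; within the scatter).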

Compound 4, half-maximal effective concentration: 459 nM
Beside the measured number, compound 4's estimate is 2.2-fold (0.34 log units) above it; measured number inside the range.
By their numbers in this assay, from the lowest: compounds 4, 2, 3 and 1 (each within the scatter of the next, the first and the last beyond it).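

In this assay, methyl in place of hydrogen on the phenyl gives a 2.7-fold lower number from compound 1 to compound 4 (0.44 log units; beyond the scatter), so compound 1 is no longer the only measured case in which a substituent on this phenyl lowers the number, and the substituent need not be an isopropyl. Exchanging 4-isopropylphenyl for 2-methylphenyl, next to the ring nitrogen of the five-membered aromatic ring, gives a 1.3-fold lower number from compound 2 to compound 4 (0.13 log units; within the scatter), so these two substituted phenyl groups cannot be told apart in this series, even though 2-methylphenyl has fewer heavy atoms. Nothing available explains either step.

From the compounds shown here alone, whether 2-methylphenyl would give a comparable step on the core of compound 3 remains open. Also open, going by these compounds, is how a methoxy group, a chlorine or an amine in place of the methyl would read in this assay.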